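Adding a Nitro Group to the 4-Fluorophenyl Ring

The compounds below may be only part of what the source reports. "The series", "measured", "known", "first", "only" and "open" are said of these compounds alone.

Compound 1, `CCOC(=O)C1=Cc2ccccc2OC1(OCc1cn(-c2ccc(F)cc2)nn1)C(F)(F)F`: 9100 nM
Compound 2, `O=C(O)C1=Cc2ccccc2OC1(OCc1cc(-c2ccc([N+](=O)[O-])cc2)no1)C(F)(F)F`: > 150000 nM

For the measured compounds named here, in a functional assay on MCF7 cells (Homo sapiens) for inhibition, read by MTT assay, with a stated time of 24 h (on this read-out higher numbers stand for weaker inhibition and lower numbers for stronger inhibition), compound 1 gives 9100 nM, the only plain number measured here. Compound 2 sits at the limit of > 150000 nM in this assay, at which 1 of the 2 values shown sits, so for it only a limit is known. Going by the values given here, compound 2 also differs from compound 1 in several places at once, so the pair gives no single step to learn from.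

Compound 3, `CCOC(=O)C1=Cc2ccccc2OC1(OCc1cn(-c2ccc(F)c([N+](=O)[O-])c2)nn1)C(F)(F)F`, differs from compound 1 by nitro in place of hydrogen on an aromatic carbon.

Among the compounds with values here, with no comparable step measured, the change a 1.1-fold higher number from compound 1 to compound 3 (0.04 log units; within the scatter) is expected to stay within the usual scatter, in no clear direction. Compound 3 is therefore estimated at 10000 nM, plausibly between 3000 nM and 35000 nM.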

Compound 3, half-maximal inhibitory concentration: 16200 nM
Compound 3: middle estimate off by 1.6-fold (0.21 log units), on the low side; low and high end bracket the measured number.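

In this assay, for the compounds shown here, the first step that changes one place is putting a nitro group on the 4-fluorophenyl ring, ortho to the fluoro group, which gives a 1.8-fold higher number from compound 1 to compound 3 (0.25 log units; within the scatter) and so leaves the two compounds indistinguishable on this read-out. This ring position therefore accepts nitro in place of hydrogen with no clear loss or gain. Nothing measured here accounts for this result. As far as these compounds go, whether an amine or a nitrile at this same position would behave alike remains open, as does the effect of nitro elsewhere on the ring.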